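The source may report more compounds than this note shows. Statements on the series, on what has been measured and on what is new or still open speak of the compounds shown alone.

Of the compounds shown here, three that share one core have been measured in an assay on isolated protein for inhibition of Dihydrofolate reductase (Homo sapiens), read by spectrophotometry, using NADPH, with stated times of 5 s and 6 min, tested at 5 uM; on this read-out lower numbers stand for a weaker effect and higher numbers for a stronger effect at the one concentration tested. Compound 1 `NC1=NC2(CCSCC2)N(OCCCOc2cccc(Cl)c2)C(N)=N1` gives 88.3% in this assay. Compound 2 `NC1=NC2(CCOCC2)N(OCCCOc2ccc(Cl)cc2)C(N)=N1` is reported in this assay only as a limit of the assay, > 90%, not as a number. Compound 3 `NC1=NC2(CCSCC2)N(OCCCOc2ccc(Br)cc2)C(N)=N1` likewise gives a limit, > 90%. Compound 2 therefore stands at the limit of > 90% in this assay, at which 2 of the 3 values shown sit. Going by the values given here, the one measured step, a number at least 1.7 percentage points higher from compound 1 to compound 3 (that floor lies within the scatter), changes both the halogen and the group it starts from, so it bears only loosely on the change from compound 2 to the not yet measured compound 4 `NC1=NC2(CCOCC2)N(OCCCOc2ccc(Br)cc2)C(N)=N1`, which is bromo in place of chloro on an aromatic carbon. No step beyond the scatter is expected. Compound 4 is estimated at 92%, between 85% and 97%, an expected step that the limit leaves unreadable from compound 2 to compound 4.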

Compound 4, a percentage reported as inhibition, at one concentration (the size of the read-out at that concentration, not a potency): > 90%
Compound 4: no number, only a limit (the forecaster's own chance of this, stated with the estimate: 70%); the middle value does not contradict the limit.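

Going by these compounds alone, compound 2 and compound 4 are both reported in this assay only as limits of the assay, not as numbers, so no step between them can be read. The compounds shown leave open whether bromo in place of chloro changes the inhibition at all.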